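The source may report more compounds than this note shows. Statements on the series, on what has been measured and on what is new or still open speak of the compounds shown alone.

Measured so far in a functional assay on Jurkat cells (Homo sapiens) for inhibition; on this read-out lower numbers stand for stronger inhibition and higher numbers for weaker inhibition:
compound 1 `CCOC(=O)c1cnc(NN2C(=O)C=C(C)C2=O)nc1C(F)(F)F` gives 2000 nM
compound 2 `CCOC(=O)c1cnc(NN2C(=O)C(C)=C(C)C2=O)nc1C(F)(F)F` gives 3900 nM
compound 3 `CCOC(=O)c1cnc(N(C(=O)OCC)N2C(=O)C=C(C)C2=O)nc1C(F)(F)F` gives 380 nM

Compound 1 holds the second highest of the three numbers in this assay. Its nearest neighbour is compound 2, reached by a 2.0-fold higher number from compound 1 to compound 2 (0.29 log units; within the scatter); its furthest is compound 3, reached by a 5.3-fold lower number from compound 1 to compound 3 (0.72 log units; beyond the scatter), a modest gain.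

Compound 4 `CCOC(=O)c1cnc(NN2C(=O)C=C(C)C2=O)nc1-c1cccs1` is the next member. Relative to compound 1 it carries thiophen-2-yl in place of trifluoromethyl on an aromatic carbon. Neither measured step bears on this exchange: the step from compound 1 to compound 2 puts methyl in place of hydrogen on a double-bonded ring carbon, and the step from compound 1 to compound 3 puts ethoxycarbonyl in place of hydrogen on a nitrogen on an aromatic ring. Both leave the trifluoromethyl untouched, so the series gives no reading of how this assay responds to a change at this aromatic carbon. For the measured compounds named here, the two recorded changes at other places moved the number either within the scatter or modestly, which is the only guide available.

Going by the values given here, with no direct precedent, the step from compound 1 to compound 4 is expected to be a 1.3-fold higher number from compound 1 to compound 4 (0.10 log units; within the scatter), held loosely in either direction. For compound 4 the estimate in this assay is 2500 nM, with a range from 600 nM to 10000 nM.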

Compound 4, half-maximal inhibitory concentration: 140 nM
Compound 4: middle estimate off by 18-fold (1.25 log units), on the high side; measured number below the stated range.
By their numbers in this assay, from the lowest: compound 4; then compound 3; then compounds 1 and 2 (each within the scatter of the next).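

In this assay, for the compounds shown here, the aromatic carbon next to the ring nitrogen and ortho to the ethoxycarbonyl group proves to be a sensitive place: thiophen-2-yl in place of trifluoromethyl gives a 14-fold lower number from compound 1 to compound 4 (1.15 log units; beyond the scatter), a large step and the first reading at this position. The trifluoromethyl group is therefore not needed for inhibition on this read-out in the core of compound 1, and this position accepts a five-membered aromatic ring with one hetero atom while the number falls. No measurement at hand explains the size of this step or separates the contributions of the leaving and entering groups.

Still open, going by these compounds, is whether the gain belongs to thiophen-2-yl itself or would also appear with a phenyl ring, a furan-2-yl ring, or a small non-aromatic group such as methyl at this aromatic carbon. Also open, on these data alone, is whether thiophen-2-yl at this position and the ethoxycarbonyl group on the nitrogen, which gave a 5.3-fold lower number from compound 1 to compound 3 (0.72 log units; beyond the scatter), would add up, stay level or work against each other when carried on the same molecule.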